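This account rests on a few compounds, and the source may have more. Where it says the series, first, only, none or still open, it means among the compounds named here.

Measured so far in a functional assay on CHO cells for antagonist activity at prostaglandin E2 receptor EP3 subtype (Homo sapiens), read by cAMP accumulation; on this read-out higher numbers stand for weaker inhibition and lower numbers for stronger inhibition:
compound 1 `CC(C)C(c1ncco1)c1ccc(-c2ccc3cccc(F)c3c2)[nH]c1=O` gives 64 nM
compound 2 `CC(C)C(c1cnc(N)s1)c1ccc(-c2ccc3cccc(F)c3c2)[nH]c1=O` gives 39 nM

On these two numbers compound 1 stands highest, with compound 2 nearest by a 1.6-fold lower number from compound 1 to compound 2 (0.22 log units; within the scatter); since that step is within the scatter, the two cannot really be told apart. Compound 3 `CC(C)C(CC(N)=O)c1ccc(-c2ccc3cccc(F)c3c2)[nH]c1=O` has not yet been measured in this assay. It differs from compound 1 by carbamoylmethyl in place of 1,3-oxazol-2-yl on a saturated chain carbon bound to an aromatic carbon and a saturated chain carbon. Going by the values given here, the one measured step at the same place, a 1.6-fold lower number from compound 1 to compound 2 (0.22 log units; within the scatter), swapped one five-membered aromatic ring for another and stayed within the scatter; no measured step trades the ring for an open chain, so the data give no direct guide. An acyclic carbamoylmethyl is a larger departure than that ring swap, so a modest weakening is expected, with wide uncertainty. Compound 3 is therefore estimated at 150 nM, with a range from 40 nM to 600 nM, which means an expected step of a 2.3-fold higher number from compound 1 to compound 3 (0.37 log units; beyond the scatter).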

Compound 3, half-maximal inhibitory concentration: 53 nM
The estimate for compound 3 lay 2.8-fold (0.45 log units) above the measured number; measured number inside the range.
By their numbers in this assay, from the lowest: compounds 2, 3 and 1 (each within the scatter of the next).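

In this assay, putting the open carbamoylmethyl chain in place of the 1,3-oxazol-2-yl ring gives a 1.2-fold lower number from compound 1 to compound 3 (0.08 log units; within the scatter) and putting it in place of the 2-amino-1,3-thiazol-5-yl ring gives a 1.4-fold higher number from compound 2 to compound 3 (0.13 log units; within the scatter) at this saturated chain carbon. Going by these compounds alone, the earlier pair exchanged only one five-membered aromatic ring for another, whereas these steps show that, across these three compounds, an aromatic ring at this place is not needed to keep the number within the scatter, even though carbamoylmethyl has one hydrogen-bond donor and 1,3-oxazol-2-yl has none. The data at hand offer no explanation for this tolerance.

From the compounds shown here alone, it remains open whether the amide of the carbamoylmethyl group matters, or whether a carboxylic acid, an amine or a longer chain would serve equally well at this carbon. Also open, going by these compounds, is which group here, if any, would move the number beyond the scatter.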